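A Methylsulfanyl Variant of the Furan Nucleoside

The source may hold more compounds than are shown below. What is called first, only, known or untested is meant among the compounds shown, and "the series" means these compounds.

Compound 1 `COc1ncnc2c1c(-c1ccoc1)cn2[C@@H]1O[C@H](CO)[C@@H](O)[C@H]1O` gives 2820 nM in a functional assay on K562 cells (Homo sapiens), read by MTT assay, with a stated time of 72 h (a lower number here means a stronger inhibitor, a higher number a weaker inhibitor), the lowest of the numbers measured here. Compound 2 `COc1ncnc2c1c(-c1cccs1)cn2[C@@H]1O[C@H](CO)[C@@H](O)[C@H]1O` gives 6200 nM in this assay. For compound 3 `COc1ncnc2c1c(-c1ccccc1)cn2[C@@H]1O[C@H](CO)[C@@H](O)[C@H]1O` this assay records only a limit, > 20000 nM. The measured steps, a 2.2-fold higher number from compound 1 to compound 2 (0.34 log units; beyond the scatter) and an at least 3.2-fold higher number from compound 2 to compound 3 (0.50 log units; beyond the scatter), both exchange the aryl group, and the largest, an at least 7.0-fold higher number from compound 1 to compound 3 (0.85 log units; beyond the scatter), rests on (the limit of > 20000 nM in this assay, at which 1 of the 3 values shown sits). Compound 4 `CSc1ncnc2c1c(-c1ccoc1)cn2[C@@H]1O[C@H](CO)[C@@H](O)[C@H]1O` differs from compound 1 elsewhere: methylsulfanyl in place of methoxy on an aromatic carbon. Within the data shown here, none of the measured steps touches this position, so no direct guide exists, and the change is expected to stay small in this assay. Compound 4 is estimated at 3200 nM, between 1000 nM and 10000 nM. The step of a 1.1-fold higher number from compound 1 to compound 4 (0.05 log units; within the scatter) is therefore expected to lie within the scatter.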

Compound 4, half-maximal inhibitory concentration: 3250 nM
Compound 4: middle estimate off by 1.0-fold (0.01 log units), on the low side; measured number inside the range.
By their numbers in this assay, from the lowest: compounds 1, 4 and 2 (each within the scatter of the next, the first and the last beyond it). At a limit, above all of these: compound 3.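

In this assay, the step, a 1.2-fold higher number from compound 1 to compound 4 (0.06 log units; within the scatter), shows that methylsulfanyl can replace methoxy on this aromatic carbon, with furan-3-yl kept, without a change beyond the scatter. The earlier steps shown here all exchanged the aryl group, so they said nothing about this position. No measurement shown offers a reason for this result. Going by these compounds, whether the exchange behaves the same with thiophen-2-yl or phenyl on the shared core stays open. So does the effect of an amine or a longer chain such as ethylsulfanyl at this position.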